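The source may report more compounds than this note shows. Statements on the series, on what has been measured and on what is new or still open speak of the compounds shown alone.

Three closely related compounds were taken into an ADME assay on microsomes from liver (Mus musculus) for metabolic stability, with a stated time of 10 min (on this read-out higher numbers stand for a more stable compound and lower numbers for a less stable compound), and the record they left is thin. For compound 1 (`CCC[C@]1(C(=O)N2CC[C@](c3ccc(C(F)(C(F)(F)F)C(F)(F)F)cc3)(S(=O)(=O)c3ccc(F)cc3)C2)CC[C@H](C(=O)O)CC1`) the entry reads "not determined" (no result reported). Going by the values given here, compound 2 (`COC[C@]1(C(=O)N2CC[C@](c3ccc(C(F)(C(F)(F)F)C(F)(F)F)cc3)(S(=O)(=O)c3ccc(F)cc3)C2)CC[C@H](C(=O)O)CC1`) gave 88%, the only number available in the set. Compound 3 (`O=C(O)[C@H]1CC[C@](F)(C(=O)N2CC[C@](c3ccc(C(F)(C(F)(F)F)C(F)(F)F)cc3)(S(=O)(=O)c3ccc(F)cc3)C2)CC1`) also has no number, its entry reading "not determined" (no result reported), so it holds no place on the scale of this read-out and can serve only as a structural starting point.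

Compound 4 (`O=C(O)C12CCC(C(=O)N3CC[C@](c4ccc(C(F)(C(F)(F)F)C(F)(F)F)cc4)(S(=O)(=O)c4ccc(F)cc4)C3)(CC1)OC2`) has yet to be measured in this assay. The change that leads to it is a group of 11 heavy atoms (8 carbon, 3 oxygen; one six-membered non-aromatic ring of carbon only, one six-membered non-aromatic ring with 1 hetero atom) in place of a group of 10 heavy atoms (7 carbon, 2 oxygen, 1 fluorine; one six-membered non-aromatic ring of carbon only), on a carbonyl carbon. The 4-carboxy-1-fluorocyclohexyl group leaves and a group with no common name enters, on a carbonyl carbon whose other neighbours are: amide-type nitrogen in a ring.

Among the compounds with values here, with no value for compound 3, no measured step can be carried over, and no step of a particular size or direction can be expected from that starting point. Within the data shown here, the sole guide is compound 2 at 88%, and a modest drop from that level, perhaps not beyond the scatter, seems the reasonable expectation given the new group. Compound 4 is expected at about 80%, with an estimated range of 60% to 95%.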

Compound 4, percent of the compound remaining: 94%
Beside the measured number, compound 4's estimate is 14 percentage points below it; low and high end bracket the measured number.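

Going by these compounds alone, at the place on a carbonyl carbon whose other neighbour is the amide-type nitrogen in a ring, the group of 12 heavy atoms in compound 2 gives way in compound 4 to a group of 11 heavy atoms with a second six-membered ring holding 1 hetero atom, and this assay shows a number 6 percentage points higher from compound 2 to compound 4 (within the scatter), so the first pair with numbers at this place shows two different groups that the read-out does not tell apart. Steps that involve compound 1 or compound 3 cannot be read, so the propyl-type and fluoro-bearing groups at this place stay without a comparison. No supporting data bear on why the read-out holds level across this exchange.

The compounds shown leave open whether the result would hold with an amine or a primary amide in place of the carboxylic acid that all of them carry, or with a nitrogen in place of the ring oxygen of compound 4. They also leave open how a longer chain on this group would read, and whether the same picture would appear at a stated time other than the one used here.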